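This account rests on a few compounds, and the source may have more. Where it says the series, first, only, none or still open, it means among the compounds named here.

Compound 1 `Cc1cc(NC(=O)Nc2cccc(C(F)(F)F)c2)c2ccccc2n1`: > 25000 nM
Compound 2 `Cc1cc(NC(=O)Nc2ccc(N)cc2)c2ccccc2n1`: > 25000 nM
Compound 3 `Cc1cc(NC(=O)Nc2cccc(Cl)c2)c2ccccc2n1`: not yet measured

Of the compounds shown here, two have been tested so far in an ADME assay on BJ cells (Homo sapiens) for cytotoxicity, with a stated time of 72 h; on this read-out lower numbers stand for an effect already at smaller amounts and higher numbers for an effect only at larger amounts of compound. Compound 1 gives > 25000 nM, which is a limit of the assay and not a number. Compound 2 gives > 25000 nM, which is also a limit and not a number. Among the compounds with values here, compound 2 thus stands at the limit of > 25000 nM in this assay, at which 2 of the 2 values shown sit, so no number is available for it, and no measured step exists to serve as a guide.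

Compound 3 keeps the shared core and the urea-type link of compound 2 but carries 3-chlorophenyl in place of 4-aminophenyl on an amide-type nitrogen.

In this assay, no change beyond the usual scatter is expected from this replacement, and so no direction is predicted. That expectation rests on compound 1, whose value is the limit > 25000 nM. It rests equally on compound 2, whose value is the limit > 25000 nM. The estimate is a number no higher from compound 2 to compound 3 (the limit leaves the size open), an expected step that stays within the scatter. Compound 3 is expected to lie near 25000 nM, with an estimated range from 10000 nM to 50000 nM.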

Compound 3, half-maximal effective concentration: > 25000 nM
Compound 3: only a limit was reported; the forecaster's own chance of this, stated with the estimate: 80%; the middle value sits exactly at the limit.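

In this assay compound 3 gives > 25000 nM, which is a limit of the assay and not a number. No step from compound 1 or compound 2 to compound 3 can be read: the limit of > 25000 nM in this assay, at which 3 of the 3 values shown sit.

The compounds shown leave open whether exchanging these groups changes the read-out, since none of the three yields a number.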